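Pyridin-4-yl in Place of a Dichlorofluorophenyl Side Group

The source may report more compounds than this note shows. Statements on the series, on what has been measured and on what is new or still open speak of the compounds shown alone.

Measured compounds:
compound 1, `CC(Nc1ncnc2ncc(-c3cnn(C)c3)cc12)c1c(Cl)ccc(F)c1Cl`: > 100000 nM
compound 2, `COc1cccc(CNc2ncnc3ccc(-c4cnn(C)c4)cc23)c1`: 28500 nM

In a functional assay on MDA-MB-231 cells (Homo sapiens) for antiproliferative activity, read by MTT assay, with a stated time of 72 h (a lower number here means a stronger inhibitor, a higher number a weaker inhibitor), compound 1 gives a limit rather than a number, > 100000 nM, which is the limit of > 100000 nM in this assay, at which 1 of the 2 values shown sits. Compound 2, built on a different core, gives 28500 nM. Compound 3 `CC(Nc1ncnc2ncc(-c3cnn(C)c3)cc12)c1ccncc1` differs from compound 1 by pyridin-4-yl in place of 2,6-dichloro-3-fluorophenyl on a saturated chain carbon bound to a nitrogen on an aromatic ring and a saturated chain carbon. For the measured compounds named here, no measured pair shows what such a change does, so the direction is uncertain; a modest move toward stronger inhibition is expected, an at least 1.6-fold lower number from compound 1 to compound 3 (0.22 log units; that floor lies within the scatter). Compound 3 is estimated at about 60000 nM, between 15000 nM and 200000 nM.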

Compound 3, half-maximal inhibitory concentration: > 100000 nM
Compound 3 was reported as a limit (the forecaster's own chance of this, stated with the estimate: 50%); at least 1.6-fold (0.22 log units) between middle value and limit.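

Compound 1 and compound 3 are both reported only as limits in this assay, so no step can be read between them: the limit of > 100000 nM in this assay, at which 2 of the 3 values shown sit.

On these data alone, whether pyridin-4-yl in place of 2,6-dichloro-3-fluorophenyl strengthens or weakens inhibition remains open.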